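An Acetoxy Variant of Compound 2

The source may hold more compounds than are shown below. What is called first, only, known or untested is meant among the compounds shown, and "the series" means these compounds.

For the measured compounds named here, in a functional assay on A549 cells (Homo sapiens) for antiproliferative activity, read by XTT assay, with a stated time of 72 h (a higher number here means a weaker inhibitor, a lower number a stronger inhibitor), compound 1 (`C=C(C)CCC[C@]1(C)C2=CCC[C@](C)(C[C@@H](OC(C)=O)C3=CC(=O)OC3O)[C@H]2CC[C@H]1C`) gives 3200 nM and compound 2 (`C=C(C)CC[C@]1(C)C2=CCC[C@](C)(C[C@@H](O)C3=CC(=O)OC3O)[C@H]2CC[C@H]1C`) gives 4400 nM, so compound 2 stands within the scatter of the only other measured value. Compound 3 (`C=C(C)CC[C@]1(C)C2=CCC[C@](C)(C[C@@H](OC(C)=O)C3=CC(=O)OC3O)[C@H]2CC[C@H]1C`) differs from compound 2 by hydroxy to acetoxy, with acetyl in place of hydrogen on an oxygen on a saturated carbon. Compound 1 also carries an acetoxy group and reads 3200 nM, so no large change is expected. The expected step, a 1.3-fold lower number from compound 2 to compound 3 (0.10 log units; within the scatter), is small, leans to a lower number and stays within the scatter in this assay. For compound 3 the estimate is 3500 nM, with an expected range of 1600 nM to 7500 nM.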

Compound 3, half-maximal inhibitory concentration: 11100 nM
Beside the measured number, compound 3's estimate is 3.2-fold (0.50 log units) below it, and the stated range ends below it.
By their numbers in this assay, from the lowest: compounds 1 and 2 (each within the scatter of the next); then compound 3.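

In this assay, acetyl in place of hydrogen on an oxygen on a saturated carbon gives a 2.5-fold higher number from compound 2 to compound 3 (0.40 log units; beyond the scatter) and so changes the reading at this position beyond the scatter. With the acetoxy group held constant, 1-methylethenyl in place of 2-methylprop-2-en-1-yl on a saturated chain carbon gives a 3.5-fold higher number from compound 1 to compound 3 (0.54 log units; beyond the scatter), so the chain matters as well. The data shown give no reason for either step. As far as these compounds go, whether a methyl ether or a benzoyl ester on that oxygen reads like the acetoxy group stays open, as does the effect of a longer chain.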